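Saturated branched chain in place of the diene

A few compounds are considered here, and "the series" means these few. Any claim that something is new, unique, unknown or untested is made for them only; others in the source may bear on it.

Compound 1 `CCC/C=C/C=C/c1cc(C#N)ccc1COC(c1ccc(C#N)cc1)c1cncn1C` carries a hepta-1,3-dien-1-yl chain on the shared core. In a functional assay on NIH3T3 cells (Mus musculus) (on this read-out lower numbers stand for an effect already at smaller amounts and higher numbers for an effect only at larger amounts of compound), compound 1 gives 16.7 nM, the highest of the two numbers in the set. Compound 3 `Cn1cncc1C(OCc1ccc(C#N)cc1C#Cc1ccccc1)c1ccc(C#N)cc1` gives 0.1 nM in this assay, so the change is a 170-fold lower number from compound 1 to compound 3 (2.22 log units; beyond the scatter). For compound 2 `Cn1cncc1C(OCc1ccc(C#N)cc1C#Cc1cccc(O)c1)c1ccc(C#N)cc1` the this assay reports only a limit, > 0.1 nM. The steps a step that the limit leaves unreadable from compound 1 to compound 2 and a number no higher from compound 2 to compound 3 (the limit leaves the size open) remain unreadable in size owing to the limit of > 0.1 nM in this assay, at which 1 of the 3 values shown sits.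

Compound 4 `Cn1cncc1C(OCc1ccc(C#N)cc1CCC(C)(C)C)c1ccc(C#N)cc1` has not yet been measured. It differs from compound 1 by 3,3-dimethylbutyl in place of hepta-1,3-dien-1-yl on an aromatic carbon. For the measured compounds named here, the one readable step, from compound 1 to compound 3, put a 2-phenylethynyl group in the same place; the 3,3-dimethylbutyl group of compound 4 has no ring and no double bond, and no measured compound carries such a chain. Going by the values given here, with no comparable step, the expectation for compound 4 is a step of a 3.0-fold higher number from compound 1 to compound 4 (0.48 log units; beyond the scatter) in this assay. The estimate for compound 4 is 50 nM, expected to fall between 10 nM and 400 nM.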

Compound 4, half-maximal effective concentration: 0.54 nM
Beside the measured number, compound 4's estimate is 93-fold (1.97 log units) above it, and the stated range ends above it.
By their numbers in this assay, from the lowest: compound 3; then compound 4; then compound 1.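

In this assay, the change to 3,3-dimethylbutyl on this aromatic carbon gives a 31-fold lower number from compound 1 to compound 4 (1.49 log units; beyond the scatter). A chain with no ring and no double bonds outside aromatic rings can therefore carry a much lower number than the hepta-1,3-dien-1-yl chain, so neither a ring nor unsaturation is required at this position for that gain. The 2-phenylethynyl group still holds a lead over this saturated branched chain, with a 5.4-fold higher number from compound 3 to compound 4 (0.73 log units; beyond the scatter), yet most of the distance between compound 1 and compound 3 is covered without any ring.

Compound 2 is known only as a limit, and its step to compound 4 cannot be read: the limit of > 0.1 nM in this assay, at which 1 of the 4 values shown sits. From the compounds shown here alone, it remains open whether a straight hexyl chain, or a chain ending in an amine, would keep the number of compound 4.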